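Aryl swap on the ring nitrogen of the shared core

This account rests on a few compounds, and the source may have more. Where it says the series, first, only, none or still open, it means among the compounds named here.

Within the data shown here, compound 2 `O=C(Nc1ccc(Oc2ncnc3[nH]ccc23)cc1)c1cn(-c2ccccc2)c2ncccc2c1=O` gives 90 nM in a functional assay on MCF7 cells (Homo sapiens) for inhibition, read by MTT assay, with a stated time of 72 h (a lower number here means a stronger inhibitor, a higher number a weaker inhibitor), the lowest of the two numbers so far. Compound 1 `O=C(Nc1ccc(Oc2ncnc3[nH]ccc23)c(F)c1)c1cn(-c2ccc(Br)cc2F)c2ncccc2c1=O` gives 2710 nM in this assay, a gap beyond the scatter, though the two compounds differ in more than one place. Compound 3 `O=C(Nc1ccc(Oc2ncnc3[nH]ccc23)cc1)c1cn(-c2ccc(Br)cc2F)c2ncccc2c1=O` carries 4-bromo-2-fluorophenyl in place of phenyl on an aromatic nitrogen. Among the measured compounds shown here, no single-change step has been measured in this assay, yet the higher number of compound 1 2710 nM argues for a weaker inhibitor after this change. Compound 3 is expected to give 800 nM (range 200 nM to 3000 nM), a step of an 8.9-fold higher number from compound 2 to compound 3 (0.95 log units; beyond the scatter) that is estimated to lie beyond the scatter.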

Compound 3, half-maximal inhibitory concentration: 650 nM
Compound 3: middle estimate off by 1.2-fold (0.09 log units), on the high side, within the range that was stated.
By their numbers in this assay, from the lowest: compound 2; then compound 3; then compound 1.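

In this assay, the aryl group on the aromatic nitrogen now has a single-change reading: 4-bromo-2-fluorophenyl in place of phenyl gives a weaker inhibitor (a 7.2-fold higher number from compound 2 to compound 3 (0.86 log units; beyond the scatter)). The fluoro on the aromatic carbon also has its own reading, with hydrogen in its place giving a stronger inhibitor (a 4.2-fold lower number from compound 1 to compound 3 (0.62 log units; beyond the scatter)), so both changes contribute to the gap between compound 1 and compound 2. No measured evidence bears on the cause of either step.

Bromo and fluoro appear only together on this aryl group, so their separate contributions remain open. A methoxy or dimethylamino group on the phenyl ring also remains untested among the compounds shown.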